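The source may report more compounds than this note shows. Statements on the series, on what has been measured and on what is new or still open speak of the compounds shown alone.

Compound 1 (`O=C1CCCCC/C1=C\c1ccccc1`) is the plain parent of this small series. In a functional assay on P388 cells (Mus musculus) for inhibition (a lower number here means a stronger inhibitor, a higher number a weaker inhibitor), compound 1 gives > 50000 nM, which is a limit of the assay and not a number. It is the only one of the three measured compounds at the limit of > 50000 nM in this assay, at which 1 of the 3 values shown sits.

Two relatives carry a halogen on the aromatic ring. Compound 2 (`O=C1CCCCC/C1=C\c1cccc(Cl)c1`) gives 25700 nM, and compound 3 (`O=C1CCCCC/C1=C\c1cccc(Br)c1`) gives 24100 nM. The measured steps are an at least 1.9-fold lower number from compound 1 to compound 2 (0.28 log units; that floor lies within the scatter) and an at least 2.0-fold lower number from compound 1 to compound 3 (0.31 log units; beyond the scatter). Between the two halogens, the step is a 1.1-fold lower number from compound 2 to compound 3 (0.03 log units; within the scatter).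

Compound 4 (`Cc1ccc(/C=C2\CCCCCC2=O)cc1`) changes compound 1 differently: methyl in place of hydrogen on an aromatic carbon. This puts methyl in place of hydrogen on an aromatic carbon, para to a group of 9 heavy atoms. For the measured compounds named here, no measured compound carries methyl, so the halogen steps are only a loose guide, and their true size is hidden by the limit.

A small move towards a lower number in this assay is expected, an estimated at least 1.6-fold lower number from compound 1 to compound 4 (0.22 log units; that floor lies within the scatter). For compound 4 the expected value is 30000 nM, with an estimated range from 14000 nM to 50000 nM.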

Compound 4, half-maximal inhibitory concentration: > 50000 nM
Compound 4: only a limit was reported; the forecaster's own chance of this, stated with the estimate: 35%; middle value at least 1.6-fold (0.22 log units) away from the limit.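

In this assay compound 1 and compound 4 each give only a limit of the assay, not a number, so the step between them cannot be read. How far methyl in place of hydrogen moves the number stays open, with both compounds sitting at the same limit: the limit of > 50000 nM in this assay, at which 2 of the 4 values shown sit.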